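Aryl amine swap on the shared core: nitro to dimethoxy

This account rests on a few compounds, and the source may have more. Where it says the series, first, only, none or still open, it means among the compounds named here.

Compound 1 `FC(F)(F)c1ccc(CSc2nc(N3CCCCC3)c3ccccc3n2)cc1` gives 28400 nM in a functional assay on MDA-MB-231 cells (Homo sapiens) for cytotoxicity, read by MTT assay, with a stated time of 72 h; a higher number here means a weaker inhibitor, a lower number a stronger inhibitor. Compound 2 `CCOc1ccccc1Nc1nc(SCc2ccc(C(F)(F)F)cc2)nc2ccccc12` reaches only the assay limit, > 50000 nM, which is the limit of > 50000 nM in this assay, at which 1 of the 3 values shown sits. Compound 3 `O=[N+]([O-])c1ccc(Nc2nc(SCc3ccc(C(F)(F)F)cc3)nc3ccccc23)cc1` gives 8670 nM in this assay, the lowest of the two numbers; the steps of a 3.3-fold lower number from compound 1 to compound 3 (0.52 log units; beyond the scatter) and an at least 5.7-fold lower number from compound 2 to compound 3 (0.76 log units; beyond the scatter) both lie beyond the scatter. Compound 4 `COc1cc(Nc2nc(SCc3ccc(C(F)(F)F)cc3)nc3ccccc23)cc(OC)c1` carries 3,5-dimethoxyphenyl in place of 4-nitrophenyl on a nitrogen on an aromatic ring. The step from compound 2 to compound 3 bears most directly on it: replacing 2-ethoxyphenyl by 4-nitrophenyl on that nitrogen gave an at least 5.7-fold lower number from compound 2 to compound 3 (0.76 log units; beyond the scatter), and compound 4 runs the opposite way, so a higher number than compound 3 is expected, of roughly that size. Compound 4 is estimated at 30000 nM in this assay, with a range from 9000 nM to 80000 nM. The step of a 3.5-fold higher number from compound 3 to compound 4 (0.54 log units; beyond the scatter) is the expected outcome.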

Compound 4, half-maximal inhibitory concentration: 16100 nM
Beside the measured number, compound 4's estimate is 1.9-fold (0.27 log units) above it, within the range that was stated.
By their numbers in this assay, from the lowest: compounds 3, 4 and 1 (each within the scatter of the next, the first and the last beyond it). At a limit, above all of these: compound 2.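

In this assay, 3,5-dimethoxyphenyl on that nitrogen is not separated from 4-nitrophenyl, a 1.9-fold higher number from compound 3 to compound 4 (0.27 log units; within the scatter), so the nitro group is not required at this position. Replacing piperidin-1-yl gives a 1.8-fold lower number from compound 1 to compound 4 (0.25 log units; within the scatter), whereas the 4-nitrophenyl version gave a 3.3-fold lower number from compound 1 to compound 3 (0.52 log units; beyond the scatter). The 2-ethoxyphenyl result for compound 2 is a limit, not a number, yet the step still reads an at least 3.1-fold lower number from compound 2 to compound 4 (0.49 log units; beyond the scatter).

Going by these compounds, whether 4-aminophenyl or 4-carboxyphenyl on that nitrogen would match these values remains open. So does whether 2-methoxyphenyl would behave like 2-ethoxyphenyl.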